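A Pentyl Chain on the Phenyl of Compound 3

The source may hold more compounds than are shown below. What is called first, only, known or untested is meant among the compounds shown, and "the series" means these compounds.

Of the compounds shown here, three have been measured in a functional assay on RAW264.7 cells (Mus musculus) for inhibition, with a stated time of 4 days; a lower number here means a stronger inhibitor, a higher number a weaker inhibitor. Compound 1 `COc1cc(/C=C/C(=O)c2cccc(-n3cc(-c4ccccc4)nn3)c2)ccc1O` gives 16800 nM, compound 2 `COc1cc(/C=C/C(=O)c2cccc(-n3cc(-c4ccccc4C(F)(F)F)nn3)c2)ccc1O` gives 5070 nM, and compound 3 `COc1ccc(/C=C/C(=O)c2cccc(-n3cc(-c4ccccc4)nn3)c2)cc1O` gives 1510 nM, the lowest of the three numbers. The step of a 3.3-fold lower number from compound 1 to compound 2 (0.52 log units; beyond the scatter) came with trifluoromethyl in place of hydrogen on an aromatic carbon, and the step of an 11-fold lower number from compound 1 to compound 3 (1.05 log units; beyond the scatter) with 3-hydroxy-4-methoxyphenyl in place of 4-hydroxy-3-methoxyphenyl on a double-bonded chain carbon. Compound 4 `CCCCCc1ccc(-c2cn(-c3cccc(C(=O)/C=C/c4ccc(OC)c(O)c4)c3)nn2)cc1` differs from compound 3 by pentyl in place of hydrogen on an aromatic carbon. Only the trifluoromethyl step bears on this change, and it was modest, so a modest step downward in this assay is expected. Compound 4 is therefore estimated at 700 nM, within 200 nM to 2500 nM. That estimate means an expected 2.2-fold lower number from compound 3 to compound 4 (0.33 log units; beyond the scatter).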

Compound 4, half-maximal inhibitory concentration: > 30000 nM
Compound 4 was reported as a limit (the forecaster's own chance of this, stated with the estimate: 5%); middle value at least 42-fold (1.63 log units) away from the limit.
By their numbers in this assay, from the lowest: compound 3; then compound 2; then compound 1. At a limit, above all of these: compound 4.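

Compound 4 gives > 30000 nM in this assay as a limit of the assay and not as a number. Pentyl on an aromatic carbon, para to a large group, brought an at least 19-fold higher number from compound 3 to compound 4 (1.29 log units; beyond the scatter) in place of the drop seen with trifluoromethyl, which brought a 3.3-fold lower number from compound 1 to compound 2 (0.52 log units; beyond the scatter) on the same phenyl. Added groups on this phenyl therefore do not all lower the number, and pentyl here raises it sharply. Still open, as far as these compounds go, is how a shorter chain such as methyl or ethyl would behave at this place. From the compounds shown here alone, an amine or a carboxylic acid there is equally open.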